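Replacing the aniline ring on a weak antiproliferative series

A few compounds are considered here, and "the series" means these few. Any claim that something is new, unique, unknown or untested is made for them only; others in the source may bear on it.

Compound 1 `COc1cc2ncnc(Nc3ccc(Cl)c(C(F)(F)F)c3)c2cc1OCCCCC(=O)Nc1ccc(S(N)(=O)=O)cc1`: 9270 nM
Compound 2 `COc1cc2ncnc(Nc3cccc(F)c3)c2cc1OCCCCC(=O)Nc1ccc(S(N)(=O)=O)cc1`: > 40000 nM
Compound 3 `COc1cc2ncnc(Nc3ccc(F)c(Br)c3)c2cc1OCCCCC(=O)Nc1ccc(S(N)(=O)=O)cc1`: 16000 nM

Three compounds share one core and differ only in the aryl group attached to the nitrogen on the aromatic ring. In a functional assay on A549 cells (Homo sapiens) for antiproliferative activity, read by MTT assay, with a stated time of 72 h (a higher number here means a weaker inhibitor, a lower number a stronger inhibitor), compound 3 and compound 1 lie within the scatter of each other, as a 1.7-fold higher number from compound 1 to compound 3 (0.24 log units; within the scatter) shows. For compound 2 the result is only a limit, > 40000 nM, not a number (the limit of > 40000 nM in this assay, at which 1 of the 3 values shown sits). From there, an at least 4.3-fold higher number from compound 1 to compound 2 (0.63 log units; beyond the scatter) and an at least 2.5-fold lower number from compound 2 to compound 3 (0.39 log units; beyond the scatter) both reach beyond the scatter, so the 3-fluorophenyl ring is clearly the weakest of the three anilines, while the two other rings cannot be told apart.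

Compound 4 `CCc1ccc(Nc2ncnc3cc(OC)c(OCCCCC(=O)Nc4ccc(S(N)(=O)=O)cc4)cc23)cc1` carries the same core with a further ring: 4-ethylphenyl in place of 3-bromo-4-fluorophenyl on a nitrogen on an aromatic ring. Going by the values given here, no measured step covers this exact exchange; the closest evidence is that two aryl rings bearing two substituents gave similar numbers while the single-fluorine ring gave a limit. A 4-ethylphenyl group is expected to land near compound 3, with a 1.3-fold higher number from compound 3 to compound 4 (0.10 log units; within the scatter) in this assay and a real chance of another limit. Compound 4 is estimated at 20000 nM, within 8000 nM to 60000 nM.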

Compound 4, half-maximal inhibitory concentration: 12100 nM
Compound 4: the middle estimate sits 1.7-fold (0.22 log units) above what was measured, and the stated range covers the measured number.
By their numbers in this assay, from the lowest: compounds 1, 4 and 3 (each within the scatter of the next). At a limit, above all of these: compound 2.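

Going by these compounds alone, the 4-ethylphenyl ring is the first on this nitrogen to hold no fluorine, chlorine or bromine, only its 8 carbon atoms, yet in this assay it cannot be told apart from the two rings that carry halogens, as a 1.3-fold lower number from compound 3 to compound 4 (0.12 log units; within the scatter) and a 1.3-fold higher number from compound 1 to compound 4 (0.12 log units; within the scatter) show. A ring with a single group can therefore sit level with the rings bearing two groups, so having one group does not by itself place a ring with the 3-fluorophenyl ring, as an at least 3.3-fold lower number from compound 2 to compound 4 (0.51 log units; beyond the scatter) shows. Compound 2 remains a limit and not a number, so that last step gives only a minimum size: the limit of > 40000 nM in this assay, at which 1 of the 4 values shown sits.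

The 3-fluorophenyl and 4-ethylphenyl rings differ both in the group and in the number in its name, so the compounds shown cannot separate these two changes, and a 4-fluorophenyl or a 3-ethylphenyl ring would be needed to do so. On these data alone, it also remains open whether an amine, a carboxylic acid or a longer chain such as butyl on this ring would move the number beyond the scatter around compound 1, compound 3 and compound 4.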